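This account rests on a few compounds, and the source may have more. Where it says the series, first, only, none or still open, it means among the compounds named here.

Measured so far in a functional assay on SK-MEL-5 cells (Homo sapiens) for cytotoxicity, read by sulforhodamine B assay, with a stated time of 48 h; a lower number here means a stronger inhibitor of growth, a higher number a weaker inhibitor of growth:
- compound 1 `ClCc1ccc(Cn2cnc3c(Cl)ncnc32)cc1`: 20900 nM
- compound 2 `ClCc1cccc(Cn2cnc3ncnc(Cl)c32)c1`: 18200 nM

Both numbers sit close together; compound 1 and compound 2 lie within the scatter of each other, so no order between them is claimed on these two points alone. Both are weak inhibitors of growth in this assay.

The next member, compound 3 `ClCc1ccc(Cn2cnc3c(Cl)nc(Cl)nc32)cc1`, is built from compound 1 by one change: chloro in place of hydrogen on an aromatic carbon. Among the compounds with values here, no pair of measured compounds shows this change, so the size of the step has no precedent. Within the data shown here, with only an added chloro on the shared core, and no measured step to lean on, the expectation for the step from compound 1 to compound 3 is a small one, a 1.4-fold lower number from compound 1 to compound 3 (0.14 log units; within the scatter), not clearly beyond the scatter in either direction.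

On that basis compound 3 is expected to give about 15000 nM in this assay, with a plausible range from 5000 nM to 50000 nM.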

Compound 3, concentration for total growth inhibition: 19100 nM
Compound 3: middle estimate off by 1.3-fold (0.10 log units), on the low side; the range from low to high includes it.
By their numbers in this assay, from the lowest: compounds 2, 3 and 1 (each within the scatter of the next).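

In this assay, chloro in place of hydrogen on an aromatic carbon between two ring nitrogen atoms gives a 1.1-fold lower number from compound 1 to compound 3 (0.04 log units; within the scatter), the first step read at this position of the shared core. On this single pair, the position tolerates the added chloro without a change beyond the scatter, so no order between the two compounds is claimed and all three compounds remain weak inhibitors of growth. Nothing in the available data offers an explanation for this flat step.

As far as these compounds go, whether an amine, a methoxy group or a longer chain at this position would move the number beyond the scatter stays open. Also open, from the compounds shown here alone, is whether the same chloro on the core of compound 2 would give a similarly small step.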